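The compounds below may be only part of what the source reports. "The series", "measured", "known", "first", "only" and "open" are said of these compounds alone.

Of the compounds shown here, three of one series have been measured in a physicochemical assay for solubility, in phosphate buffer, measured as kinetic solubility, at pH 7.4 (a higher number here means a more soluble compound, a lower number a less soluble compound), and all three sit at the upper edge of what the method reports. Compound 1 `Cc1ccccc1-c1nc(CN2CCC(C(=O)NCCCN3CCC(C)CC3)CC2)c(C)o1` in this assay gives > 67 ug/mL, which is a limit of the assay and not a number. Compound 2 `Cc1ccccc1-c1nc(CN2CCC(C(=O)NCCCN3CCCCC3)CC2)c(C)o1` differs from it by hydrogen in place of methyl on a saturated ring carbon, and in this assay compound 2 gives > 65 ug/mL, again a limit. The step that the two limits leave unreadable from compound 1 to compound 2 is therefore unreadable. Compound 3 `Cc1oc(-c2c(Cl)cccc2Cl)nc1CN1CCC(C(=O)NCCCN2C[C@H](C)C[C@H](C)C2)CC1` in this assay gives > 77 ug/mL, which is likewise a limit. Each of the three values shown rests at such a limit, namely (the limit of > 65 ug/mL in this assay, at which 1 of the 3 values shown sits), the limit of > 67 ug/mL in this assay, at which 1 of the 3 values shown sits, and (the limit of > 77 ug/mL in this assay, at which 1 of the 3 values shown sits), so no readable step exists in the series.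

Compound 4 `Cc1cc(C)cc(-c2nc(CN3CCC(C(=O)NCCCN4C[C@H](C)C[C@H](C)C4)CC3)c(C)o2)c1` differs from compound 3 by 3,5-dimethylphenyl in place of 2,6-dichlorophenyl on an aromatic carbon. For the measured compounds named here, no measured step bears on this change, since every step is hidden behind limits. With the three measured compounds all at the limit, compound 4 is expected to sit near 70 ug/mL, with a range from 30 ug/mL to 160 ug/mL. The step of an at least 1.1-fold lower number from compound 3 to compound 4 (0.04 log units; that floor lies within the scatter) is expected to be no larger than the scatter, and the assay will most likely again report only a limit.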

Compound 4, solubility: > 71 ug/mL
Compound 4 gave a limit, no number; the forecaster's own chance of this, stated with the estimate: 70%; middle value at least 1.0-fold (0.00 log units) from the limit.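

In this assay compound 4 gives > 71 ug/mL, a limit of the assay and not a number. Compound 3 gives > 77 ug/mL, also a limit. The step between compound 3 and compound 4 therefore cannot be read. The compounds shown leave open how far 3,5-dimethylphenyl in place of 2,6-dichlorophenyl moves the result in this assay, and where the true value of any of the four compounds lies.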